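Pyrrolidinyl for diethylamino on a nicotinamide-type series

This account rests on a few compounds, and the source may have more. Where it says the series, first, only, none or still open, it means among the compounds named here.

Measured so far:
- compound 1, `O=C(Nc1cc(C(F)(F)F)ccc1N1CCCC1)c1cccnc1`: "not active" (no number reported)
- compound 2, `O=C(Nc1cc(C(F)(F)F)ccc1Nc1ccc(Br)cc1)c1cccnc1Cl`: 35700 nM
- compound 3, `CCN(CC)c1ccc(C(F)(F)F)cc1NC(=O)c1cccnc1Cl`: "not active" (no number reported)

Three compounds sharing the same amide-linked core have been run in a functional assay on NALM-6 cells (Homo sapiens) for cytotoxicity, read by MTT assay, with a stated time of 48 h; on this read-out higher numbers stand for weaker inhibition and lower numbers for stronger inhibition. Compound 1 is recorded as "not active" (no number reported), so no number stands for it. Among the compounds with values here, compound 2 gives 35700 nM, the only numerical value in the set, and a weak one. Compound 3 is likewise recorded as "not active" (no number reported); it stands without a number, alongside one further entry that also lacks one, so no ranking of compound 3 against the others can be drawn.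

Compound 4, `O=C(Nc1cc(C(F)(F)F)ccc1N1CCCC1)c1cccnc1Cl`, is the next to be measured in this assay . It differs from compound 3 in a single place: pyrrolidin-1-yl in place of diethylamino on an aromatic carbon. Compound 4 shares with compound 1 the pyrrolidin-1-yl group, and compound 1 is without activity; compound 3, the direct parent, is also without activity. Within the data shown here, no step between measured compounds is available, so no size for this change can be read from the data. In this assay the expectation is therefore no shift beyond the scatter, with the reported outcome most likely again a limit rather than a number.

Compound 4 is estimated at 60000 nM, within 20000 nM to 200000 nM.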

Compound 4, half-maximal inhibitory concentration: "not active" (no number reported)
No number was reported for compound 4, and the estimate cannot be compared.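

In this assay, within the data shown here, compound 3 gives "not active" (no number reported) and compound 4 gives "not active" (no number reported), so no step for pyrrolidin-1-yl in place of diethylamino can be read between them. No measurement at hand bears on this result. The compounds shown leave open whether this exchange shifts cytotoxicity at all.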